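Swapping an ether link for a nitrile-bearing benzyl group

This account rests on a few compounds, and the source may have more. Where it says the series, first, only, none or still open, it means among the compounds named here.

Of the compounds shown here, three sharing one core have been tested in an ADME assay on HepG2 cells (Homo sapiens) for cytotoxicity, read by luminescence, CellTiter-Glo and ATP content, with a stated time of 72 h; a higher number here means that more compound is needed for the effect, a lower number that less compound is needed. Compound 1 `c1ccc(Oc2ccc3c(NCCCNCc4ccco4)ccnc3c2)cc1` gives 15200 nM. Compound 2 `COc1cccc(CNCCCNc2ccnc3cc(Cc4ccc(C#N)cc4)ccc23)c1O` gives 7150 nM. Compound 3 `COc1cccc(Oc2ccc3c(NCCCNCc4ccco4)ccnc3c2)c1` gives 15500 nM, the highest of the three numbers; compound 1 sits within the scatter of it, and only compound 2 is clearly lower, beyond the scatter.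

Among the compounds with values here, the one measured step that touches compound 3 is a 1.0-fold higher number from compound 1 to compound 3 (0.01 log units; within the scatter), so adding that methoxy group changed nothing that can be trusted.

Compound 4 `N#Cc1ccc(Cc2ccc3c(NCCCNCc4ccco4)ccnc3c2)cc1` is reached from compound 3 by a different kind of change: 4-cyanobenzyl in place of 3-methoxyphenoxy on an aromatic carbon. Within the data shown here, no measured pair isolates this exact swap. Among the measured compounds shown here, what the numbers do show is that compound 2, the only one carrying the 4-cyanobenzyl group, reads lower than both ether-linked compounds, though its amine end also differs. A modest drop toward that value is therefore expected, with wide uncertainty.

Compound 4 is estimated at 9500 nM, within 4000 nM to 22000 nM, an expected step of a 1.6-fold lower number from compound 3 to compound 4 (0.21 log units; within the scatter).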

Compound 4, half-maximal effective concentration: 7910 nM
Compound 4: middle estimate off by 1.2-fold (0.08 log units), on the high side; the measured number falls inside the stated range.
By their numbers in this assay, from the lowest: compounds 2, 4, 1 and 3 (each within the scatter of the next, the first and the last beyond it).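

In this assay, the change from an ether-linked aromatic group to 4-cyanobenzyl on this aromatic carbon can now be read with the amine end held constant: a 2.0-fold lower number from compound 3 to compound 4 (0.29 log units; within the scatter) starting from 3-methoxyphenoxy and a 1.9-fold lower number from compound 1 to compound 4 (0.28 log units; within the scatter) starting from phenoxy, so neither swap gives a difference that can be trusted. With 4-cyanobenzyl held fixed, the amine end can be read as well, and a 1.1-fold higher number from compound 2 to compound 4 (0.04 log units; within the scatter) shows that furan-2-yl in place of 2-hydroxy-3-methoxyphenyl also gives no reliable difference. Nothing available offers an explanation for these steps.

The compounds shown leave open whether the nitrile or the carbon link matters at all on this aromatic carbon. A plain benzyl group and a 4-cyanophenoxy group at the same place would separate the two.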